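Ethyl for methyl on the para substituent: a second look

This account rests on a few compounds, and the source may have more. Where it says the series, first, only, none or still open, it means among the compounds named here.

Measured compounds:
compound 1 `COc1ccc(C2C(Oc3ccccc3)C(=O)N2c2cc(OC)c(OC)c(OC)c2)cc1` gives 52 nM
compound 2 `COc1cc(N2C(=O)C(C3CC3)C2c2ccc(SC)cc2)cc(OC)c1OC` gives 204 nM
compound 3 `CCOc1ccc(C2C(Oc3ccccc3)C(=O)N2c2cc(OC)c(OC)c(OC)c2)cc1` gives 388 nM

All three were run in a functional assay on HT-29 cells (Homo sapiens) for inhibition, read by sulforhodamine B assay, with a stated time of 72 h; a higher number here means a weaker inhibitor, a lower number a stronger inhibitor. Compound 1 and compound 3 share one core and differ in a single place: methyl in place of hydrogen on a saturated chain carbon bound to an oxygen on an aromatic ring. This change gave a 7.5-fold higher number from compound 1 to compound 3 (0.87 log units; beyond the scatter). Compound 2 sits on another core, and the difference between the two cores is not broken down here. In this assay compound 2 stands nearest to compound 3, within the scatter, and apart from compound 1, beyond it.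

Compound 4 `CCSc1ccc(C2C(C3CC3)C(=O)N2c2cc(OC)c(OC)c(OC)c2)cc1` is not yet measured. It differs from compound 2 by methyl in place of hydrogen on a saturated chain carbon bound to a sulfur. For the measured compounds named here, this is the same kind of change as the one from compound 1 to compound 3, but not the same: there the carbon carrying the new methyl was bound to an oxygen on an aromatic ring, here it is bound to a sulfur, and the surrounding core is also different.

For compound 4 the step is expected to run in the same direction, toward a weaker inhibitor, as a 2.9-fold higher number from compound 2 to compound 4 (0.47 log units; beyond the scatter), smaller than the earlier step because it is supported only by a 7.5-fold higher number from compound 1 to compound 3 (0.87 log units; beyond the scatter) on another core and at a different kind of atom. The estimate for compound 4 is therefore 600 nM, with a plausible range from 200 nM to 2000 nM.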

Compound 4, half-maximal inhibitory concentration: 1560 nM
For compound 4 the middle estimate is 2.6-fold (0.41 log units) below the measured one; the measured number falls inside the stated range.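

In this assay the change from methylsulfanyl to ethylsulfanyl gives a 7.6-fold higher number from compound 2 to compound 4 (0.88 log units; beyond the scatter), and the same kind of change on the two cores agrees in direction and in size: the same change on two cores in this assay, a 7.5-fold higher number (0.87 log units; beyond the scatter) from compound 1 to compound 3 and a 7.6-fold higher number (0.88 log units; beyond the scatter) from compound 2 to compound 4, 1.0-fold (0.01 log units) apart, within the scatter of two such steps

For these two pairs, the step toward a weaker inhibitor therefore carries over from the core of compound 1 to the core of compound 2, even though the carbon receiving the new methyl is bound to an oxygen on an aromatic ring in one pair and to a sulfur in the other. This does not explain the loss of activity, and two pairs cannot establish a rule for other cores or show how much the core and the bound atom each contribute, since they vary together here.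

The compounds shown leave open how the trend continues beyond ethyl, for instance with a propyl or isopropyl group at the same place on either core. They also leave open whether a chain carrying an amine or a carboxylic acid would follow the same step, and whether the step would appear with the core of compound 1 bearing a sulfur or the core of compound 2 bearing an oxygen.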